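A few compounds are considered here, and "the series" means these few. Any claim that something is new, unique, unknown or untested is made for them only; others in the source may bear on it.

Three amides sharing one core have been measured. Compound 1 `CCC(=O)N1CC2CC(C1)N2` gives 120% in an assay on CHO cells for agonist activity at Neuronal acetylcholine receptor; alpha3/alpha6/beta2/beta3 (Homo sapiens), read by FLIPR and calcium flux; on this read-out higher numbers stand for larger maximal responses and lower numbers for smaller maximal responses. Compound 2 `O=C(C1CCCC1)N1CC2CC(C1)N2` gives 62% in this assay, and compound 3 `O=C(C1CC=CC1)N1CC2CC(C1)N2` gives 99%. Compound 1 stands highest of the three, with compound 3 nearest and compound 2 furthest, both gaps lying beyond the usual scatter. Compound 4 `O=C([C@H]1C[C@H]1F)N1CC2CC(C1)N2` has not yet been measured in this assay. It differs from compound 1 by 2-fluorocyclopropyl in place of ethyl on a carbonyl carbon. Since compound 2 with 62% and compound 3 with 99% both sit below compound 1, a downward step a number 20 percentage points lower from compound 1 to compound 4 (beyond the scatter) beyond the scatter is expected. Compound 4 is estimated to reach 100%, with a likely range from 70% to 130%.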

Compound 4, largest response reached (Emax), in percent of the reference or control that the assay uses: 130%
Compound 4: the middle estimate sits 30 percentage points below what was measured; measured number inside the range.
By their numbers in this assay, from the lowest: compound 2; then compound 3; then compounds 1 and 4 (each within the scatter of the next).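

In this assay, 2-fluorocyclopropyl in place of ethyl on a carbonyl carbon gives a number 10 percentage points higher from compound 1 to compound 4 (within the scatter) and so shows that this position can carry a ring without the response dropping. Until now, compound 2 at 62% and compound 3 at 99% had shown only lower numbers with a ring at this place. The compounds shown leave open how plain cyclopropyl or the mirror-image 2-fluorocyclopropyl would read here, and so whether the fluorine, the small ring or the stereocentres matter. No evidence on the cause of this result is at hand.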